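The source may report more compounds than this note shows. Statements on the series, on what has been measured and on what is new or still open speak of the compounds shown alone.

Measured compounds:
Compound 1, `Cc1cccc(C(=O)/C=C/c2ccc3c(c2)B(O)OC3)c1`; in an ADME assay on L929 cells (Mus musculus) for cytotoxicity, read by resazurin assay, with a stated time of 72 h (a lower number here means a stronger inhibitor, a higher number a weaker inhibitor), compound 1 gives 8.56 ug/mL.
Compound 2, `O=C(/C=C/c1ccc2c(c1)B(O)OC2)c1ccc(F)cc1`; in this assay compound 2 gives only a limit of the assay, > 10 ug/mL.

Compound 2 therefore stands at the top of the measured range in this assay: no number is known for it, only its entry at the limit of > 10 ug/mL in this assay, at which 1 of the 2 values shown sits. Going by the values given here, the single measured step, an at least 1.1-fold higher number from compound 1 to compound 2 (0.06 log units; that floor lies within the scatter), is likewise only a floor and lies within the scatter, so it carries no direction of its own.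

Compound 3, `CSc1ccc(C(=O)/C=C/c2ccc3c(c2)B(O)OC3)cc1`, differs from compound 2 by methylsulfanyl in place of fluoro on an aromatic carbon. Among the compounds with values here, no measured step touches methylsulfanyl; the one step available changes 3-methylphenyl to 4-fluorophenyl on the carbonyl carbon and stays within the scatter. With nothing pointing either way, the expected step in this assay is an at least 1.0-fold lower number from compound 2 to compound 3 (0.02 log units; that floor lies within the scatter), that is, no change beyond the scatter. Compound 3 is accordingly estimated at 9.5 ug/mL, within 4.5 ug/mL to 20 ug/mL, with a real chance that the assay again reports only a limit for compound 3.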

Compound 3, half-maximal inhibitory concentration: > 10 ug/mL
Compound 3: no number, only a limit; the forecaster's own chance of this, stated with the estimate: 45%; at least 1.0-fold (0.02 log units) between middle value and limit.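

In this assay compound 3 gives > 10 ug/mL, a limit of the assay and not a number. Compound 2 also carries only a limit, so no step between compound 2 and compound 3 can be read: the limit of > 10 ug/mL in this assay, at which 2 of the 3 values shown sit.

The compounds shown leave open whether methylsulfanyl and fluoro differ at all in this assay, since neither compound has a measured number.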